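Two Inactive Compounds and a Third Still to Come

The source may report more compounds than this note shows. Statements on the series, on what has been measured and on what is new or still open speak of the compounds shown alone.

Compound 1 `COc1ccc(-c2cc(/C=C/C(=O)c3ccc(N)cc3)[nH]n2)cc1` and compound 2 `COc1cc(-c2cc(/C=C/C(=O)c3ccc(Cl)c(Cl)c3)[nH]n2)cc(OC)c1OC` were both tested in a functional assay on NCI-H226 cells (Homo sapiens) for cytotoxicity, read by sulforhodamine B assay, with a stated time of 48 h, tested at 0.01 uM; a higher number here means a weaker effect of the compound at the concentration tested, a lower number a stronger effect. In this assay compound 1 gives 102%. Compound 2 gives 103%, a number that lies within the usual scatter of what compound 1 shows, so the two cannot be told apart: at this concentration neither compound reduces the cells measurably. Compound 3 `COc1ccc(C(=O)/C=C/c2cc(-c3cc(OC)c(OC)c(OC)c3)n[nH]2)cc1` has not yet been measured in this assay. It differs from compound 2 in one place: 4-methoxyphenyl in place of 3,4-dichlorophenyl on a carbonyl carbon. For the measured compounds named here, no measured pair here shares that change, so nothing in the data sets the size of its effect. Because compound 2 gives 103%, compound 3 is expected to behave much the same. The step of a number 2 percentage points lower from compound 2 to compound 3 (within the scatter) is expected to stay within the scatter. The estimate for compound 3 is 101%, with a range from 90% to 112%.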

Compound 3, a percentage reported as activity, at one concentration (the size of the read-out at that concentration, not a potency): 99%
Estimate against measurement, compound 3: 2 percentage points above, and the stated range covers the measured number.
By their numbers in this assay, from the lowest: compounds 3, 1 and 2 (each within the scatter of the next).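

Placing 4-methoxyphenyl in place of 3,4-dichlorophenyl on a carbonyl carbon gives a number 4 percentage points lower from compound 2 to compound 3 (within the scatter), so compound 2 and compound 3 cannot be told apart in this assay. For the compounds shown here, this is the first pair here that differs in one place, and it shows that exchanging these two aromatic groups, one carrying two chlorine atoms and the other a methoxy group, produces no detectable difference at the single concentration tested. No measured information is available to explain the size of this step.

Going by these compounds, with all three compounds showing no measurable effect on the cells, it remains open whether this position matters at all under conditions where a compound does reduce the cells. A carboxylic acid or a butoxy chain on this ring might give a different result, and the values shown cannot predict it.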